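The source may hold more compounds than are shown below. What is called first, only, known or untested is meant among the compounds shown, and "the series" means these compounds.

In a functional assay on GOTO cells (Homo sapiens) for cytotoxicity, read by MTT assay, with a stated time of 3 days (on this read-out lower numbers stand for stronger inhibition and higher numbers for weaker inhibition), compound 1 `N#Cc1c(O)nc(SCc2nc3ccccc3[nH]2)nc1-c1ccccc1` gives 7.81 nM and compound 2 `N#Cc1c(Nc2nccs2)nc(SCc2nc3ccccc3[nH]2)nc1-c1ccccc1` gives 5.1 nM. Within the data shown here, these two values lie within the scatter of each other, so compound 2 cannot be separated from compound 1 on the numbers so far. Compound 3 `N#Cc1c(NNC(N)=S)nc(SCc2nc3ccccc3[nH]2)nc1-c1ccccc1` shares the core of compound 2 and differs from it in one place: a group of 4 heavy atoms (1 carbon, 2 nitrogen, 1 sulfur; no ring) in place of a group of 5 heavy atoms (3 carbon, 1 nitrogen, 1 sulfur; one five-membered aromatic ring with 2 hetero atoms), on a nitrogen on an aromatic ring. Among the measured compounds shown here, only one measured step bears on this change, a 1.5-fold lower number from compound 1 to compound 2 (0.19 log units; within the scatter), and it also alters the group on that part of the core. That single step gives no sign of a large effect, although it says little about an open chain in place of the ring. No shift beyond the scatter is therefore expected in this assay, in either direction. The expected step is a 1.2-fold higher number from compound 2 to compound 3 (0.07 log units; within the scatter). For compound 3 the estimated value is 6 nM, with an expected range from 2 nM to 20 nM.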

Compound 3, half-maximal inhibitory concentration: 2.55 nM
For compound 3 the middle estimate is 2.4-fold (0.37 log units) above the measured one; measured number inside the range.
By their numbers in this assay, from the lowest: compounds 3, 2 and 1 (each within the scatter of the next, the first and the last beyond it).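

In this assay, an open chain takes the place of the 1,3-thiazol-2-yl on the nitrogen and the number stays within the scatter (a 2.0-fold lower number from compound 2 to compound 3 (0.30 log units; within the scatter)), so among these compounds a ring at this place is not needed for a low nanomolar value. Among these compounds, the same chain also gives the first step in this short series that lies beyond the scatter, a modest one (a 3.1-fold lower number from compound 1 to compound 3 (0.49 log units; beyond the scatter)), whereas compound 2 could not be separated from compound 1. Nothing measured here accounts for either step.

Going by these compounds, it remains open how much of the chain is needed on the aromatic carbon, since a plain amine there would test its shortest form. The chain's sulfur is equally unresolved, and the same chain with an oxygen atom in its place would address that.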